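The source may report more compounds than this note shows. Statements on the series, on what has been measured and on what is new or still open speak of the compounds shown alone.

Measured so far:
compound 1, `COc1ccc(C(=O)/C=C/c2cc(-c3cc(OC)c(OC)c(OC)c3)n[nH]2)cc1OC`, -89%
compound 2, `COc1cc(-c2cc(/C=C/C(=O)c3ccc(F)c(F)c3)[nH]n2)cc(OC)c1OC`, 4%

For the measured compounds named here, in a functional assay on OVCAR-8 cells (Homo sapiens) for cytotoxicity, read by sulforhodamine B assay, with a stated time of 48 h, tested at 10 uM (a lower number here means a stronger effect, a higher number a weaker effect of the compound at the concentration tested), compound 1 stands lowest of the two numbers; the only step known, a number 93 percentage points higher from compound 1 to compound 2 (beyond the scatter), exchanges the whole aryl group on the carbonyl carbon. Compound 3, `COc1cc(C(=O)/C=C/c2cc(-c3cc(OC)c(OC)c(OC)c3)n[nH]2)cc(OC)c1OC`, differs from compound 1 by methoxy in place of hydrogen on an aromatic carbon. Going by the values given here, no measured step adds a methoxy at such a place, and the known step bears on it only loosely. Expected is therefore no step beyond the scatter, a number 4 percentage points higher from compound 1 to compound 3 (within the scatter). The estimate for compound 3 is -85%, within -100% to -50%.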

Compound 3, a percentage reported as activity, at one concentration (the size of the read-out at that concentration, not a potency): -76%
Compound 3: middle estimate off by 9 percentage points, on the low side; the range from low to high includes it.
By their numbers in this assay, from the lowest: compound 1; then compound 3; then compound 2.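

In this assay, methoxy in place of hydrogen on an aromatic carbon, ortho to a methoxy group and meta to a large group, gives a number 13 percentage points higher from compound 1 to compound 3 (beyond the scatter). The step is beyond the scatter but modest, and compound 3 still reads -76%, so this position accepts the added methoxy with most of the effect of compound 1 kept. Open, as far as these compounds go, is whether a hydroxy group, an amine or a longer chain such as ethoxy at this place would keep that effect. No evidence in hand explains the step.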